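Swapping phenoxy for dimethylamino: an untested analogue

The compounds below may be only part of what the source reports. "The series", "measured", "known", "first", "only" and "open" are said of these compounds alone.

compound 1 `COc1cc(C)cc(-c2nn(CC#N)cc2-c2ccc(-c3cccc(C(C)=O)c3)nc2)c1`: 2610 nM
compound 2 `Cc1cc(O)cc(-c2nn(CC#N)cc2-c2ccnc(-c3ccc(Oc4ccccc4)cc3)c2)c1`: 2850 nM

In a functional assay on CCRF-CEM cells (Homo sapiens) for inhibition, read by sulforhodamine B assay, with a stated time of 48 h (a lower number here means a stronger inhibitor of growth, a higher number a weaker inhibitor of growth), compound 1 gives 2610 nM, and compound 2 gives 2850 nM. Compound 2 has the higher of the two numbers, but the gap to compound 1 lies within the scatter, so nothing separates them. Compound 3 `Cc1cc(O)cc(-c2nn(CC#N)cc2-c2ccnc(-c3ccc(N(C)C)cc3)c2)c1` differs from compound 2 by dimethylamino in place of phenoxy on an aromatic carbon. Among the compounds with values here, no measured pair shows this change, so the step in this assay is expected to stay within the scatter, if anything leaning toward a weaker inhibitor of growth. Compound 3 is expected to give about 3500 nM, between 1200 nM and 10000 nM. That amounts to an expected step of a 1.2-fold higher number from compound 2 to compound 3 (0.09 log units; within the scatter).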

Compound 3, concentration for 50% growth inhibition: 3590 nM
The estimate for compound 3 lay 1.0-fold (0.01 log units) below the measured number; low and high end bracket the measured number.
By their numbers in this assay, from the lowest: compounds 1, 2 and 3 (each within the scatter of the next).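

At this place, on an aromatic carbon para to a large group, phenoxy with its 7 heavy atoms and carbon ring gives way to dimethylamino with 3 heavy atoms and no ring, and this assay shows a 1.3-fold higher number from compound 2 to compound 3 (0.10 log units; within the scatter) for this change. For this pair, then, the outer ring is not needed to keep the number at this level. Nothing available explains why the two groups read alike.

Still open, on these data alone, is whether a carboxylic acid, a primary amine or a longer alkoxy chain here would move the number beyond the scatter.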